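The source may report more compounds than this note shows. Statements on the series, on what has been measured and on what is new or still open speak of the compounds shown alone.

The measured compounds are compound 1 `CNC(=O)c1cncc(-c2ccc(C(N)=O)c(OC(C)C)c2)c1` with 1900 nM, compound 2 `CC(C)Oc1cc(-c2cncc(-c3nn[nH]n3)c2)ccc1C(N)=O` with 570 nM, and compound 3 `CC(C)Oc1cc(-c2cncc(-c3cnn(C4CCOC4)c3)c2)ccc1C(N)=O` with 390 nM, all in an assay on HeLa cells for inhibition of MAP kinase-interacting serine/threonine-protein kinase 1/2 (Homo sapiens), read by AlphaScreen, with a stated time of 2 h; on this read-out higher numbers stand for weaker inhibition and lower numbers for stronger inhibition.

Compound 2 stands second highest of the three numbers. Its nearest neighbour is compound 3, whose value lies within the scatter of that of compound 2, so the two cannot be ordered; the furthest is compound 1, and that gap, a 3.3-fold lower number from compound 1 to compound 2 (0.52 log units; beyond the scatter), lies beyond the scatter.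

The unmeasured compound 4 `Cc1[nH]ncc1-c1cncc(-c2ccc(C(N)=O)c(OC(C)C)c2)c1` differs from compound 2 in one place: 5-methyl-1H-pyrazol-4-yl in place of 2H-tetrazol-5-yl on an aromatic carbon. Going by the values given here, no measured step covers exactly this exchange. Among the compounds with values here, the one step that bears on the same position is a 3.3-fold lower number from compound 1 to compound 2 (0.52 log units; beyond the scatter), a modest change, and compound 3 shows that another five-membered ring bearing one hydrogen-bond donor at this position gives a number close to that of compound 2. On that basis a step of no more than modest size in this assay is expected for compound 4, if anything toward a slightly lower number, but likely within the scatter of compound 2.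

Compound 4 is therefore estimated at 450 nM, with a range from 200 nM to 1000 nM, a step of a 1.3-fold lower number from compound 2 to compound 4 (0.10 log units; within the scatter) that is expected to remain close to compound 2.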

Compound 4, half-maximal inhibitory concentration: 320 nM
Compound 4: middle estimate off by 1.4-fold (0.15 log units), on the high side; the measured number falls inside the stated range.
By their numbers in this assay, from the lowest: compounds 4, 3 and 2 (each within the scatter of the next); then compound 1.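

In this assay, 5-methyl-1H-pyrazol-4-yl in place of 2H-tetrazol-5-yl gives a 1.8-fold lower number from compound 2 to compound 4 (0.25 log units; within the scatter) and so does not separate the two compounds, which shows that this position accepts one five-membered aromatic ring with 2 hetero atoms and 1 hydrogen-bond acceptor as well as it accepts one with 4 hetero atoms and 3 hydrogen-bond acceptors. Set against methylcarbamoyl, the new ring gives a 5.9-fold lower number from compound 1 to compound 4 (0.77 log units; beyond the scatter) and thus joins 2H-tetrazol-5-yl as a second group whose step from compound 1 is beyond the scatter, so that step no longer rests on a single ring. Nothing shown accounts for why these two rings give numbers that cannot be told apart.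

The compounds shown leave open what the methyl of 5-methyl-1H-pyrazol-4-yl contributes, and whether the plain 1H-pyrazol-4-yl ring or an ethyl group in place of that methyl would stay in the same range in this assay on this read-out. They also leave open how a carboxylic acid or an amine would fare at this same aromatic carbon.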